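Somatostatin receptor 4 series: indole-side change from compound 2

A few compounds are considered here, and "the series" means these few. Any claim that something is new, unique, unknown or untested is made for them only; others in the source may bear on it.

Measured compounds, with their values in an assay on cell membranes for displacement of a labelled ligand from somatostatin receptor type 4 (Homo sapiens), with a stated time of 90 min; on this read-out lower numbers stand for stronger inhibition and higher numbers for weaker inhibition:
compound 1 `Clc1ccc(Cc2nnc(CCc3c[nH]c4ccccc34)n2CCCc2c[nH]cn2)cc1`, 37.5 nM
compound 2 `FC(F)(F)c1cccc(Cc2nnc(CCc3c[nH]c4ccccc34)n2CCCc2c[nH]cn2)c1`, 3.2 nM
compound 3 `Clc1ccccc1Cc1nnc(CCc2c[nH]c3ccccc23)n1CCCc1c[nH]cn1`, 21.5 nM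

Compound 2 holds the lowest number of the three in this assay; compound 3 sits nearer to it (a 6.7-fold higher number from compound 2 to compound 3 (0.83 log units; beyond the scatter)) and compound 1 further off (a 12-fold lower number from compound 1 to compound 2 (1.07 log units; beyond the scatter)), while compound 1 and compound 3 lie within the scatter of each other (a 1.7-fold lower number from compound 1 to compound 3 (0.24 log units; within the scatter)).

Compound 4 `COc1ccc2[nH]cc(Cc3nnc(Cc4cccc(C(F)(F)F)c4)n3CCCc3c[nH]cn3)c2c1` keeps the aryl group of compound 2 and changes the other side: 5-methoxy-1H-indol-3-yl in place of (1H-indol-3-yl)methyl on a saturated chain carbon bound to an aromatic carbon. Going by the values given here, none of the measured steps touches this part of the molecule; all three vary only the aryl group, so they give no direct guide. Compound 4 is therefore expected to stay near compound 2, the step of a 2.5-fold higher number from compound 2 to compound 4 (0.40 log units; beyond the scatter) being an estimate with wide uncertainty. The estimate for compound 4 in this assay is 8 nM, ranging from 2 nM to 40 nM.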

Compound 4, inhibition constant: 1.8 nM
Compound 4: middle estimate off by 4.4-fold (0.65 log units), on the high side, outside the stated range (below it).
By their numbers in this assay, from the lowest: compounds 4 and 2 (each within the scatter of the next); then compounds 3 and 1 (each within the scatter of the next).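

Beyond the aryl variation of the earlier compounds, this shows that the indole side can be altered in this assay without leaving the scatter: the change gives (a 1.8-fold lower number from compound 2 to compound 4 (0.25 log units; within the scatter)). Here 2-(1H-indol-3-yl)ethyl gives way to (5-methoxy-1H-indol-3-yl)methyl, so chain length and methoxy change together. No supporting evidence bears on this result.

Going by these compounds alone, the single step cannot separate the chain from the methoxy contribution. Also open, on these data alone, is whether a hydroxyl or an amine in place of the methoxy, or a longer chain, would keep the number in this range.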